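The source may report more compounds than this note shows. Statements on the series, on what has been measured and on what is new or still open speak of the compounds shown alone.

Compound 1 `O=C1Nc2ccc(Br)cc2/C1=N/NC(=S)N/N=C/c1ccccc1Br` gives in a functional assay on HeLa cells (Homo sapiens) for inhibition, read by MTT assay (a lower number here means a stronger inhibitor, a higher number a weaker inhibitor), only a limit, > 50000 nM.
Compound 2 `Cc1ccc(O)c(/C=N/NC(=S)N/N=C2\C(=O)Nc3ccc(C)cc32)c1` gives in this assay only a limit, > 50000 nM.
Compound 3 `Cc1ccc2c(c1)/C(=N/NC(=S)N/N=C/c1c(Cl)cccc1Cl)C(=O)N2` gives in this assay 1790 nM.

Among the compounds with values here, compound 3 therefore stands as the only compound with an actual number in this assay; the other two sit at the limit of > 50000 nM in this assay, at which 2 of the 3 values shown sit. Compound 4 `Cc1ccc2c(c1)/C(=N/NC(=S)N/N=C/c1ccccc1Br)C(=O)N2` is the next step from it, and the change is 2-bromophenyl in place of 2,6-dichlorophenyl on a carbon with a double bond to nitrogen.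

Within the data shown here, one measured step bears on this place. Going an at least 27-fold lower number from compound 2 to compound 3 (1.44 log units; beyond the scatter) exchanged the aryl group on the same carbon with a double bond to nitrogen, and that exchange moved the compound from a limit to a number. Compound 1 carries the same 2-bromophenyl that enters in compound 4 but a different substituent on the shared core. In this assay compound 1 gave only a limit, > 50000 nM. Among the measured compounds shown here, no step between compound 1 and compound 4 is available, so only their two values can be set side by side.

Because of the limit of > 50000 nM in this assay, at which 2 of the 3 values shown sit, the estimate for compound 4 is expected to lie toward weaker inhibition than compound 3. The expected step is a 5.0-fold higher number from compound 3 to compound 4 (0.70 log units; beyond the scatter). For compound 4 the expected value in this assay is 9000 nM, within a range of 2500 nM to 50000 nM.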

Compound 4, half-maximal inhibitory concentration: > 50000 nM
Compound 4 was reported as a limit (the forecaster's own chance of this, stated with the estimate: 30%); middle value at least 5.5-fold (0.74 log units) away from the limit.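

In this assay, the exchange of 2,6-dichlorophenyl for 2-bromophenyl on a carbon with a double bond to nitrogen gave an at least 27-fold higher number from compound 3 to compound 4 (1.44 log units; beyond the scatter), so a single aryl exchange at this place is enough to go from a number back to a limit. Until now only the gain from 2-hydroxy-5-methylphenyl to 2,6-dichlorophenyl was on record; among the three aryl groups carried on the methyl-bearing shared core of compound 2, compound 3 and compound 4, only the 2,6-dichlorophenyl of compound 3 gives a number. The steps to compound 4 from compound 1 and from compound 2 cannot be read, since each joins two limits, so the exchange of bromo for methyl on the aromatic carbon has no size here: the limit of > 50000 nM in this assay, at which 3 of the 4 values shown sit.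

Still open, from the compounds shown here alone, is whether a 2-chlorophenyl or a 2,6-dibromophenyl group on this carbon would give a number in this assay, which would show whether one or both of the two chlorines of compound 3 matter. Going by these compounds, it is also open how an amine or a carboxylic acid on that phenyl ring would read in this assay.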